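Swapping the amide group on the shared core

The source may report more compounds than this note shows. Statements on the series, on what has been measured and on what is new or still open speak of the compounds shown alone.

In a functional assay on A549 cells (Homo sapiens) for inhibition, read by sulforhodamine B assay, with a stated time of 72 h (on this read-out lower numbers stand for stronger inhibition and higher numbers for weaker inhibition), compound 1 (`Nc1sc(-c2ccc(Cl)cc2)c(-c2ccc(Cl)cc2)c1C(=O)N1CCCC1`) gives 890 nM and stands lowest of the three measured amides. Compound 2 (`Nc1sc(-c2ccc(Cl)cc2)c(-c2ccc(Cl)cc2)c1C(=O)NCc1ccccc1`) gives 16300 nM and stands highest. Compound 3 (`Nc1sc(-c2ccc(Cl)cc2)c(-c2ccc(Cl)cc2)c1C(=O)NC1CCCC1`) gives 6790 nM and holds the middle place, nearer to compound 2 than to compound 1.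

The next amide is compound 4 (`Nc1sc(-c2ccc(Cl)cc2)c(-c2ccc(Cl)cc2)c1C(=O)N1CCNCC1`), with piperazin-1-yl in place of cyclopentylamino on a carbonyl carbon. The closest evidence runs the opposite way: cyclopentylamino in place of pyrrolidin-1-yl gave a 7.6-fold higher number from compound 1 to compound 3 (0.88 log units; beyond the scatter) and was a modest step, while benzylamino in place of pyrrolidin-1-yl gave an 18-fold higher number from compound 1 to compound 2 (1.26 log units; beyond the scatter) and was a large one. Exchange between the two open amides gave only a 2.4-fold lower number from compound 2 to compound 3 (0.38 log units; beyond the scatter) by comparison. Piperazin-1-yl resembles pyrrolidin-1-yl in compound 1 as a ring on the carbonyl carbon with no amide hydrogen, so part of the gap to compound 1 should return. Within the data shown here, no measured step compares the two rings, so a full return cannot be assumed. The expected change is a 3.4-fold lower number from compound 3 to compound 4 (0.53 log units; beyond the scatter) in this assay and points toward a lower number of modest size. The estimate for compound 4 is 2000 nM (expected range 600 nM to 7000 nM).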

Compound 4, half-maximal inhibitory concentration: 1020 nM
The estimate for compound 4 lay 2.0-fold (0.29 log units) above the measured number; low and high end bracket the measured number.
By their numbers in this assay, from the lowest: compounds 1 and 4 (each within the scatter of the next); then compound 3; then compound 2.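

In this assay, piperazin-1-yl on the carbonyl carbon gives a 6.7-fold lower number from compound 3 to compound 4 (0.82 log units; beyond the scatter) and a 16-fold lower number from compound 2 to compound 4 (1.20 log units; beyond the scatter), so this ring separates clearly from both the cyclopentylamino and the benzylamino amides, while the comparison with the other ring amide gives a 1.1-fold higher number from compound 1 to compound 4 (0.06 log units; within the scatter). Among these compounds, the position therefore accepts pyrrolidin-1-yl and piperazin-1-yl alike, despite the difference in ring size and hetero atoms, and across these four compounds the two amides without an amide hydrogen both give lower numbers than the two that carry one, with no compound going against this split. Nothing available explains this split or the match between the two rings.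

The four compounds do not separate the loss of the amide hydrogen from the presence of a ring, since every amide lacking that hydrogen here is also a ring amide; an open dialkyl amide such as dimethylamino on the carbonyl carbon would address this. Going by these compounds, whether the ring nitrogen of piperazin-1-yl contributes anything also remains open, and a morpholine ring in the same place would be a direct comparison.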